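Sulfonamide Ring Swap: Iodine Out, Two Methyls In

This account rests on a few compounds, and the source may have more. Where it says the series, first, only, none or still open, it means among the compounds named here.

compound 1 `O=C1NCCN1c1ccc(S(=O)(=O)Nc2cccc(Br)c2)cc1`: 59 nM
compound 2 `O=C1NCCN1c1ccc(S(=O)(=O)Nc2ccc(I)cc2)cc1`: 260 nM

Among the compounds with values here, in a functional assay on M21 cells (Homo sapiens) for antiproliferative activity, read by sulforhodamine B assay, with a stated time of 48 h (on this read-out higher numbers stand for weaker inhibition and lower numbers for stronger inhibition), compound 2 gives the higher of the two numbers; the single measured step, a 4.4-fold higher number from compound 1 to compound 2 (0.64 log units; beyond the scatter), lies beyond the scatter. Compound 3 `Cc1cccc(NS(=O)(=O)c2ccc(N3CCNC3=O)cc2)c1C` differs from compound 2 by 2,3-dimethylphenyl in place of 4-iodophenyl on a sulfonamide nitrogen. Within the data shown here, the one measured step bears on this change only loosely: it shows that swapping the group on the sulfonamide nitrogen shifts the number modestly, but it does not fix the direction for this new group. A step of a 1.7-fold lower number from compound 2 to compound 3 (0.24 log units; within the scatter) is therefore expected, with wide uncertainty. Compound 3 is estimated at 150 nM, within 40 nM to 600 nM.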

Compound 3, half-maximal inhibitory concentration: 110 nM
Compound 3: the middle estimate sits 1.4-fold (0.13 log units) above what was measured, within the range that was stated.
By their numbers in this assay, from the lowest: compounds 1 and 3 (each within the scatter of the next); then compound 2.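

In this assay the move to 2,3-dimethylphenyl on a sulfonamide nitrogen gives a 2.4-fold lower number from compound 2 to compound 3 (0.37 log units; beyond the scatter) and so shows that this position accepts a ring carrying no halogen. The step of a 1.9-fold higher number from compound 1 to compound 3 (0.27 log units; within the scatter) means that 2,3-dimethylphenyl and 3-bromophenyl cannot be told apart here. Nothing available accounts for these results. On these data alone, it remains open whether one methyl alone would serve as well as two, and whether a phenyl ring carrying an amine or a carboxylic acid would hold up on this nitrogen.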